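The compounds below may be only part of what the source reports. "The series", "measured", "known", "first", "only" and "open" are said of these compounds alone.

In a functional assay on MDA-MB-231 cells (Homo sapiens) for antiproliferative activity, with a stated time of 4 days (on this read-out lower numbers stand for stronger inhibition and higher numbers for weaker inhibition), compound 1 (`CCCCc1ccc2[nH]c(-c3ccc(OC)cc3)c(/C=N/NC(=O)c3ccccc3)c2c1`) gives 32 nM as its value, compound 2 (`CCCCc1ccc2[nH]c(-c3ccc(OC)cc3)c(/C=N/NC(=O)c3ccc(OC)cc3)c2c1`) gives 61 nM and compound 3 (`CCCCc1ccc2[nH]c(-c3ccc(C(F)(F)F)cc3)c(/C=N/NC(=O)c3ccc(OC)cc3)c2c1`) gives 284 nM on the same measure. Compound 2 thus lies close to compound 1 and well apart from compound 3.

The unmeasured compound 4 (`CCCCc1ccc2[nH]c(-c3ccc(OC)cc3)c(/C=N/NC(=O)c3ccc([N+](=O)[O-])cc3)c2c1`) carries nitro in place of methoxy on an aromatic carbon, and the counted difference is nitro in place of methoxy on an aromatic carbon in full.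

Among the measured compounds shown here, two measured steps bear on this change. At this same carbon, methoxy in place of hydrogen gave a 1.9-fold higher number from compound 1 to compound 2 (0.28 log units; within the scatter) and so hardly moved the number. Elsewhere in the molecule, trifluoromethyl in place of methoxy gave a 4.7-fold higher number from compound 2 to compound 3 (0.67 log units; beyond the scatter) as a modest weakening. For the measured compounds named here, no measured compound carries nitro, so both steps are only rough guides. The first suggests a small effect at this carbon and the second a drift towards weaker inhibition.

The expected change is a 1.8-fold higher number from compound 2 to compound 4 (0.26 log units; within the scatter) as a small move towards a higher number. For compound 4 the estimated value is 110 nM within an expected range from 40 nM to 300 nM in this read-out.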

Compound 4, half-maximal inhibitory concentration: 115 nM
The estimate for compound 4 lay 1.0-fold (0.02 log units) below the measured number; measured number inside the range.
By their numbers in this assay, from the lowest: compounds 1, 2 and 4 (each within the scatter of the next, the first and the last beyond it); then compound 3.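

In this assay, replacing 4-methoxyphenyl with 4-nitrophenyl on the carbonyl gave a 1.9-fold higher number from compound 2 to compound 4 (0.28 log units; within the scatter), so methoxy and nitro cannot be told apart at this carbon. Measured against hydrogen at the same carbon, nitro gave a 3.6-fold higher number from compound 1 to compound 4 (0.56 log units; beyond the scatter), a step beyond the scatter, whereas the earlier step from hydrogen to methoxy stayed within it, so this position is not wholly indifferent to what it carries. Nothing available explains why the number responds in this way.

The compounds shown leave open how an amine, a carboxylic acid or a chlorine atom at this carbon would compare with hydrogen, methoxy and nitro. They also leave open whether nitro in place of methoxy would read the same in compound 3, which has trifluoromethyl at the other ring.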